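Trimming the Ether Side Chain of Compound 1

The compounds below may be only part of what the source reports. "The series", "measured", "known", "first", "only" and "open" are said of these compounds alone.

Compounds measured so far:
compound 1 `O=c1c(Cc2coc3cccc(OCC4CCCCC4)c3c2=O)coc2ccccc12` — 4110 nM
compound 2 `O=c1c(/C=C/c2coc3ccccc3c2=O)coc2ccccc12` — > 10000 nM
compound 3 `O=c1c(Cc2coc3cccc(OCC4CCCCC4)c3c2=O)coc2cc(Cl)ccc12` — > 10000 nM

Among the measured compounds shown here, in a functional assay on MDA-MB-231 cells (Homo sapiens) for antiproliferative activity, read by XTT assay (a lower number here means a stronger inhibitor, a higher number a weaker inhibitor), compound 1 gives 4110 nM, the only actual number among the three values shown. For compound 2 the assay reports > 10000 nM, which is a limit rather than a number. Compound 3 likewise comes back at a limit, > 10000 nM. For the measured compounds named here, compound 1 therefore stands as the one compound with a measured value, and the only defined step is an at least 2.4-fold higher number from compound 1 to compound 3 (0.38 log units; beyond the scatter), whose true size is unknown because of the limit of > 10000 nM in this assay, at which 2 of the 3 values shown sit.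

Compound 4 `CC(C)COc1cccc2occ(Cc3coc4ccccc4c3=O)c(=O)c12` differs from compound 1 by isopropyl in place of cyclohexyl on a saturated chain carbon bound to an oxygen on an aromatic ring. Going by the values given here, none of the measured pairs involves this change: the chloro step from compound 1 to compound 3 concerns a different part of the molecule, and compound 2 differs at the linker. Among the compounds with values here, there is thus no measured precedent for swapping the ring for the smaller branched chain on the ether. In the absence of such evidence, the expected step is a 1.5-fold higher number from compound 1 to compound 4 (0.16 log units; within the scatter), close to the scatter, with a real chance that compound 4 is reported only at the limit. Compound 4 is estimated to give 6000 nM in this assay, with a range from 2500 nM to 15000 nM.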

Compound 4, half-maximal inhibitory concentration: > 10000 nM
Compound 4 gave a limit, no number (the forecaster's own chance of this, stated with the estimate: 35%); at least 1.6-fold (0.22 log units) between middle value and limit.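

In this assay, replacing cyclohexyl with isopropyl on the saturated chain carbon bound to an oxygen on an aromatic ring gives an at least 2.4-fold higher number from compound 1 to compound 4 (0.38 log units; beyond the scatter). Among the compounds shown here, this is the first sign that the ether side chain itself matters here, as the earlier steps showed only what happens on a change elsewhere in the molecule, and among the compounds carrying an ether side chain only compound 1, with its cyclohexylmethoxy group, reaches a number, while compound 3 keeps that same group and still does not. For compound 4 the value > 10000 nM is a limit and not a number, so the step has only a lower bound and its true size stays unknown: the limit of > 10000 nM in this assay, at which 3 of the 4 values shown sit.

The compounds shown leave open whether the loss follows the ring of cyclohexyl or simply the smaller carbon count of isopropyl, as the two differ in both. A straight hexyl chain, a phenyl ring or an amine at the end of the ether chain in place of cyclohexyl would be needed to separate these readings and to show whether this position can give a number stronger than that of compound 1.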